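The source may hold more compounds than are shown below. What is called first, only, known or untested is meant among the compounds shown, and "the series" means these compounds.

Compound 2 `C[C@@H]1CN(C(=O)c2nc(Nc3cc(C4CC4)[nH]n3)c3cc(Cl)ccc3n2)CCN1C(=O)OC(C)(C)C` is, on the two numbers in hand, the compound with the higher reading: in an ADME assay on a cell-free system (plasma, Homo sapiens), read by HPLC, with a stated time of 120 min, at 37 degrees C (a higher number here means that more of the compound is left, a lower number that less of the compound is left), compound 2 gives 73.7%, whereas compound 1 `CC(C)C(=O)OCOC(=O)N1CCN(C(=O)c2nc(Nc3cc(C4CC4)[nH]n3)c3cc(Cl)ccc3n2)C[C@H]1C` gives 6.1%. Within the data shown here, the only measured step is a number 67.6 percentage points higher from compound 1 to compound 2 (beyond the scatter), a large change that lies well beyond the scatter.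

Compound 3 `CC(OC(=O)N1CCN(C(=O)c2nc(Nc3cc(C4CC4)[nH]n3)c3cc(Cl)ccc3n2)C[C@H]1C)OC(=O)C(C)(C)C` has not yet been measured. Relative to compound 2 the change is 1-(((tert-butyl)carbonyl)oxy)ethyl in place of tert-butyl on an oxygen next to a carbonyl group. Among the measured compounds shown here, this is the same kind of exchange that separates compound 2 from compound 1, only run in the opposite direction and with a different acyloxyalkyl group, so the one measured step is the step that bears on it. Since compound 1, carrying the ((isopropylcarbonyl)oxy)methyl group, gives 6.1%, and since moving from that group to tert-butyl produced a number 67.6 percentage points higher from compound 1 to compound 2 (beyond the scatter), a large drop beyond the scatter is expected for compound 3, as the step of a number 58.7 percentage points lower from compound 2 to compound 3 (beyond the scatter). The size of that drop is uncertain, as no 1-(((tert-butyl)carbonyl)oxy)ethyl analogue has been measured here. Compound 3 is therefore estimated at 15%, within a range from 3% to 45%.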

Compound 3, percent of the compound remaining: 49.4%
Compound 3: the middle estimate sits 34.4 percentage points below what was measured; measured number above the stated range.
By their numbers in this assay, from the lowest: compound 1; then compound 3; then compound 2.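

Read in this assay, the exchange on an oxygen next to a carbonyl group is no longer a single sharp contrast, for there is a number 24.3 percentage points lower from compound 2 to compound 3 (beyond the scatter) as 1-(((tert-butyl)carbonyl)oxy)ethyl enters, a modest step set against the large one the earlier pair showed. The two larger groups are also far from interchangeable, with a number 43.3 percentage points higher from compound 1 to compound 3 (beyond the scatter) when 1-(((tert-butyl)carbonyl)oxy)ethyl stands in place of ((isopropylcarbonyl)oxy)methyl, so across these three compounds the reading follows the particular group and not merely the loss of tert-butyl. Even so, tert-butyl remains the group with the highest reading of the three, and both of its steps to the others lie beyond the scatter.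

The two larger groups differ at both the acyl end and the carbon that links it to the oxygen, so these compounds leave open which of the two parts goes with the higher reading, a question that a (((tert-butyl)carbonyl)oxy)methyl group on the same oxygen would help to separate. Nothing given here accounts for the spread among these three groups.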